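The compounds below may be only part of what the source reports. "The series", "measured", "known", "first", "only" and "open" are said of these compounds alone.

Among the compounds with values here, compound 2 `COc1ccc(N(C(=O)CN2C=CN(c3ccccc3)C(=O)C(Cc3n[nH]c4cc(F)ccc34)C2=O)C(C)C)cc1` stands lowest of the two numbers known here: in a functional assay on CHO cells for agonist activity at Melanocortin receptor 4 (Homo sapiens), read by a luciferase reporter, with a stated time of 4 h (on this read-out lower numbers stand for an effect already at smaller amounts and higher numbers for an effect only at larger amounts of compound), compound 2 gives 355 nM. Compound 1 `CC(C)N(C(=O)CN1C=CN(c2ccccc2)C(=O)C(Cc2n[nH]c3ccccc23)C1=O)c1ccccc1` gives 3240 nM in this assay, a gap beyond the usual scatter, yet these two compounds differ in two places at once, so neither place alone can be credited. Compound 3 `CC(C)N(C(=O)CN1C=CN(c2ccccc2)C(=O)C(Cc2n[nH]c3cc(F)ccc23)C1=O)c1ccccc1` differs from compound 2 in one place only: hydrogen in place of methoxy on an aromatic carbon. The step from compound 2 to compound 3 is expected to be a 2.8-fold higher number from compound 2 to compound 3 (0.45 log units; beyond the scatter), toward higher numbers, because compound 1 without the methoxy gives 3240 nM. Compound 3 is estimated at 1000 nM, within 400 nM to 2500 nM.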

Compound 3, half-maximal effective concentration: 537 nM
Compound 3: the middle estimate sits 1.9-fold (0.27 log units) above what was measured, and the stated range covers the measured number.
By their numbers in this assay, from the lowest: compounds 2 and 3 (each within the scatter of the next); then compound 1.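

In this assay, the step with hydrogen in place of methoxy is a 1.5-fold higher number from compound 2 to compound 3 (0.18 log units; within the scatter) and stays within the scatter, so with the fluoro present, this para methoxy makes no clear difference. The fluoro step, a 6.0-fold lower number from compound 1 to compound 3 (0.78 log units; beyond the scatter), lies beyond the scatter and is the one clear single-place effect so far. Nothing measured here explains either step. From the compounds shown here alone, whether methoxy would matter without the fluoro remains open. So does how an amine or a longer ether chain at that ring carbon, or chloro in place of the fluoro, would behave.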